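From 2-bromophenyl to 4-bromophenyl on an amine nitrogen

This account rests on a few compounds, and the source may have more. Where it says the series, first, only, none or still open, it means among the compounds named here.

Measured in a functional assay, with a stated time of 6 min; on this read-out higher numbers stand for weaker inhibition and lower numbers for stronger inhibition:
- compound 1 `COc1ccc(NCn2nc(-c3ccc4c(c3)OCCO4)oc2=S)cc1`: 5830 nM
- compound 2 `Fc1ccccc1NCn1nc(-c2ccc3c(c2)OCCO3)oc1=S`: 6390 nM
- compound 3 `S=c1oc(-c2ccc3c(c2)OCCO3)nn1CNc1ccccc1Br`: 12700 nM

The three compounds lie close together. Compound 1 and compound 2 cannot be told apart, with a 1.1-fold higher number from compound 1 to compound 2 (0.04 log units; within the scatter). Compound 3 separates from only one of them: there is a 2.2-fold higher number from compound 1 to compound 3 (0.34 log units; beyond the scatter), whereas the other comparison gives a 2.0-fold higher number from compound 2 to compound 3 (0.30 log units; within the scatter).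

The next compound, compound 4 `S=c1oc(-c2ccc3c(c2)OCCO3)nn1CNc1ccc(Br)cc1`, is still unmeasured in this assay. It has 4-bromophenyl in place of 2-bromophenyl on an amine nitrogen, so the two compounds have the same atoms, joined differently. Going by the values given here, no measured pair compares these two groups directly. The nearest evidence is the modest change that comes with 2-bromophenyl in place of 4-methoxyphenyl, a 2.2-fold higher number from compound 1 to compound 3 (0.34 log units; beyond the scatter). The exchange of bromo for fluoro, a 2.0-fold higher number from compound 2 to compound 3 (0.30 log units; within the scatter), bears on it less directly. Together these suggest only a small move toward a lower number, and probably none beyond the scatter. The expected step is a 1.5-fold lower number from compound 3 to compound 4 (0.17 log units; within the scatter). The estimate for compound 4 is 8500 nM, with an expected range from 3800 nM to 19000 nM.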

Compound 4, half-maximal inhibitory concentration: 14700 nM
For compound 4 the middle estimate is 1.7-fold (0.24 log units) below the measured one, within the range that was stated.
By their numbers in this assay, from the lowest: compounds 1, 2, 3 and 4 (each within the scatter of the next, the first and the last beyond it).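

In this assay, the place of the bromine on the phenyl ring carrying the amine nitrogen makes no readable difference: 2-bromophenyl and 4-bromophenyl cannot be told apart, with a 1.2-fold higher number from compound 3 to compound 4 (0.06 log units; within the scatter). Compound 4 nevertheless separates from both non-bromo compounds, with a 2.3-fold higher number from compound 2 to compound 4 (0.36 log units; beyond the scatter) and a 2.5-fold higher number from compound 1 to compound 4 (0.40 log units; beyond the scatter), both modest steps, whereas compound 3 separated only from compound 1. No measurement shown here offers an explanation for these small differences.

The compounds shown leave open whether any group on this amine nitrogen can bring the number well below those of the present set, since all four compounds lie close together and only 2-fluorophenyl, 2-bromophenyl, 4-bromophenyl and 4-methoxyphenyl are represented. Unsubstituted phenyl would show how the halogen and methoxy compounds stand against the bare ring, while a phenyl ring bearing a nitrile or a carboxylic acid would test substituents of a different kind at this position.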